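Methylsulfanyl for amino on the aryl ketone ring

This account rests on a few compounds, and the source may have more. Where it says the series, first, only, none or still open, it means among the compounds named here.

Measured so far:
compound 1, `COc1ccc2c(/C=C/C(=O)c3cc(N)c(OC)c(OC)c3)cn(C)c2c1`: 455 nM
compound 2, `COc1ccc2c(/C=C/C(=O)c3cc(OC)c(OC)c([Se]C)c3)c[nH]c2c1`: 78 nM

In a functional assay on HCT-8 cells (Homo sapiens) for antiproliferative activity, read by MTT assay, with a stated time of 48 h (on this read-out higher numbers stand for weaker inhibition and lower numbers for stronger inhibition), compound 1 gives the higher of the two numbers recorded; compound 2 gives the lower number, and the gap between them lies beyond the scatter. Within the data shown here, compound 2 differs from compound 1 in more than one place, so the two values are only set side by side and no single step is read from them.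

Compound 3, `COc1ccc2c(/C=C/C(=O)c3cc(OC)c(OC)c(SC)c3)cn(C)c2c1`, is not yet measured in this assay. Its difference from compound 1 is methylsulfanyl in place of amino on an aromatic carbon. Because compound 2 with its methylselanyl group gives 78 nM, a lower number than compound 1, the expected step of a 3.8-fold lower number from compound 1 to compound 3 (0.58 log units; beyond the scatter) is downward, beyond the scatter. Compound 3 is expected to give about 120 nM, within 40 nM to 360 nM.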

Compound 3, half-maximal inhibitory concentration: 157 nM
Compound 3: middle estimate off by 1.3-fold (0.12 log units), on the low side; low and high end bracket the measured number.
By their numbers in this assay, from the lowest: compounds 2 and 3 (each within the scatter of the next); then compound 1.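

Among these compounds, this is the first step that can be read at a single place. In this assay, methylsulfanyl in place of amino, on the aromatic carbon ortho to a methoxy group, gives a 2.9-fold lower number from compound 1 to compound 3 (0.46 log units; beyond the scatter), a modest change. The amino group's hydrogen-bond donor is therefore not needed at this position for activity in this pair, since methylsulfanyl carries none and compound 3 still gives the lower number. Nothing available accounts for the step.

Going by these compounds, whether the step depends on the sulfur or on simply removing the amino group stays open, and a hydroxyl group or a longer chain such as ethylsulfanyl at this position would test this. Also open, on these data alone, is whether the same change gives a similar step on a core other than that of compound 1.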